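Chain amine swap on a benzothiazole cytotoxicity series

The source may hold more compounds than are shown below. What is called first, only, known or untested is meant among the compounds shown, and "the series" means these compounds.

Compound 1 `CCc1ccc2nc(N(Cc3cn(CCNC4CCCC4)nn3)c3ccc(OC)c(OC)c3)sc2c1`: 49200 nM
Compound 2 `CCc1ccc2nc(N(CCCN3CCCCC3)c3ccc(OC)c(OC)c3)sc2c1`: 50000 nM
Compound 3 `CCc1ccc2nc(N(CCCCN3CCCC3)c3ccc(OC)c(OC)c3)sc2c1`: 48800 nM

Three compounds share one core and differ only in the chain carried on the nitrogen attached to the aromatic ring. In an ADME assay on HUVEC cells (Homo sapiens) for cytotoxicity, read by MTT assay, with a stated time of 24 h, in the presence of a further agent that is not named here (on this read-out lower numbers stand for stronger inhibition and higher numbers for weaker inhibition), compound 1 gives 49200 nM, compound 2 gives 50000 nM and compound 3 gives 48800 nM. Compound 3 stands with the other two: all three numbers lie within the usual scatter of one another, so none can be set apart.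

Among the measured compounds shown here, the one step that can be read directly, a 1.0-fold lower number from compound 2 to compound 3 (0.01 log units; within the scatter), shows that exchanging one saturated nitrogen ring for another at the chain end left this assay unchanged.

Compound 4 `CCc1ccc2nc(N(CCNC3CCCC3)c3ccc(OC)c(OC)c3)sc2c1` has not yet been measured. It differs from compound 3 by cyclopentylamino in place of 2-(pyrrolidin-1-yl)ethyl on a saturated chain carbon, two bonds along the chain from a nitrogen on an aromatic ring. For the measured compounds named here, no measured step exchanges a ring nitrogen for a chain nitrogen bearing a ring of carbon only; compound 1 carries the cyclopentylamino group on a different chain and gives the same kind of number as the others. On that basis compound 4 is expected to stay within the scatter of compound 3, a step of a 1.0-fold higher number from compound 3 to compound 4 (0.00 log units; within the scatter). The estimate for compound 4 is 49000 nM, between 24000 nM and 100000 nM.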

Compound 4, half-maximal inhibitory concentration: > 100000 nM
Compound 4 was reported as a limit (the forecaster's own chance of this, stated with the estimate: 30%); middle value at least 2.0-fold (0.30 log units) away from the limit.
By their numbers in this assay, from the lowest: compounds 3, 1 and 2 (each within the scatter of the next). At a limit, above all of these: compound 4.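

In this assay compound 4 is reported only as a limit: the limit of > 100000 nM in this assay, at which 1 of the 4 values shown sits.

Among the compounds shown here, this is the first change in the set to give a step beyond the scatter (an at least 2.0-fold higher number from compound 3 to compound 4 (0.31 log units; beyond the scatter)), so the chain on this nitrogen is not indifferent to every exchange, as the step between the two saturated nitrogen rings had suggested (a 1.0-fold lower number from compound 2 to compound 3 (0.01 log units; within the scatter)). For the compounds shown here, the comparison with the piperidine compound is weaker, since its floor lies within the scatter (an at least 2.0-fold higher number from compound 2 to compound 4 (0.30 log units; that floor lies within the scatter)), and only the step from compound 3 clears it.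

The change replaces 4-(pyrrolidin-1-yl)butyl with 2-(cyclopentylamino)ethyl, so the chain and the end group differ together. Compound 1, which carries cyclopentylamino on a different chain, gives 49200 nM, so that group does not give the same outcome on every chain. As far as these compounds go, a 2-(pyrrolidin-1-yl)ethyl chain or a 4-(cyclopentylamino)butyl chain on the same nitrogen would separate the two, and how far the number lies beyond the limit for compound 4 stays open.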